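The source may report more compounds than this note shows. Statements on the series, on what has been measured and on what is new or still open speak of the compounds shown alone.

Measured in an ADME assay on S9 fraction from liver (Homo sapiens) for metabolic stability, with a stated time of 1 h; a higher number here means that more of the compound is left, a lower number that less of the compound is left:

- compound 1 `N#Cc1cnc(NCc2cnccc2C(F)(F)F)cc1N[C@H]1C[C@H](O)C1`: 96%
- compound 2 `N#Cc1cnc(NCc2cnccc2C(F)(F)F)cc1N[C@H]1CC[C@@H](O)CC1`: 33%
- compound 3 `CO[C@H]1CC[C@@H](CNc2cc(NCc3cnccc3C(F)(F)F)ncc2C#N)CC1`: 4%

Compound 3 stands lowest of the three in this assay, and compound 2 is its nearest neighbour. Compound 4 `N#Cc1cnc(NCc2cnccc2C(F)(F)F)cc1NCCC1CCOCC1` is related to it by one change: (oxan-4-yl)methyl in place of 4-methoxycyclohexyl on a saturated chain carbon bound to a nitrogen on an aromatic ring. Cut one bond further out, this reads (4-methoxycyclohexyl)methyl to 2-(oxan-4-yl)ethyl, on the nitrogen on an aromatic ring.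

Among the measured compounds shown here, no measured step makes this exchange, and no measured compound carries the oxan-4-yl ring. The nearest evidence comes from steps at the same nitrogen: a number 29 percentage points lower from compound 2 to compound 3 (beyond the scatter), which is modest, and the large a number 63 percentage points lower from compound 1 to compound 2 (beyond the scatter) and a number 92 percentage points lower from compound 1 to compound 3 (beyond the scatter). These show that the read-out responds strongly to this substituent. A further fall is hardly possible because compound 3 gives 4%. A modest rise is therefore expected, smaller than the large steps, and the expected step is a number 18 percentage points higher from compound 3 to compound 4 (beyond the scatter). For compound 4 the estimated value is 22%, with an expected range from 6% to 50%.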

Compound 4, percent of the compound remaining: 23%
Compound 4: the middle estimate sits 1 percentage points below what was measured, within the range that was stated.
By their numbers in this assay, from the lowest: compound 3; then compounds 4 and 2 (each within the scatter of the next); then compound 1.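

In this assay the exchange of 4-methoxycyclohexyl for (oxan-4-yl)methyl gives a number 19 percentage points higher from compound 3 to compound 4 (beyond the scatter) and adds no hydrogen-bond donor, which shows that the read-out at this position can move up with no hydroxyl group on the substituent. Set against the hydroxylated substituents, the 4-hydroxycyclohexyl comparison gives a number 10 percentage points lower from compound 2 to compound 4 (within the scatter) while the 3-hydroxycyclobutyl comparison gives a number 73 percentage points lower from compound 1 to compound 4 (beyond the scatter) and so remains well apart. Nothing measured here accounts for these steps.

The one exchange changes the place of the oxygen, the chain length and the two defined stereocentres together, and the compounds shown do not separate these. Also open, as far as these compounds go, is how an oxan-4-yl ring set directly on the nitrogen, or a piperidine amine in its place, would read in this assay.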